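The compounds below may be only part of what the source reports. "The series", "measured", "known", "first", "only" and "open" are said of these compounds alone.

Three compounds have been measured in a functional assay on HT-29 cells (Homo sapiens) for inhibition, read by sulforhodamine B assay, with a stated time of 48 h; on this read-out lower numbers stand for stronger inhibition of growth and higher numbers for weaker inhibition of growth:

compound 1, `COc1ccc(/C=C/C2CC(=O)C=CO2)cc1OC`: 123 uM
compound 2, `COc1cc(/C=C/C2CC(=O)C=CO2)cc(OC)c1OC`: 135 uM
compound 3, `COc1ccc(/C=C/C2CC=CC(=O)O2)cc1`: 33.7 uM

Compounds 1 and 2 share one core, while compound 3 carries another; the difference between the two cores is not broken down here. Within the first pair the change is methoxy in place of hydrogen on an aromatic carbon, and it gave a 1.1-fold higher number from compound 1 to compound 2 (0.04 log units; within the scatter). Compound 3 stands apart from both: in this assay compound 3 gives the lowest number of the three, and its gaps to compound 1 and to compound 2 both lie beyond the scatter.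

Compound 4, `COc1ccc(/C=C/C2CC=CC(=O)O2)c(OC)c1`, has not been measured yet. It is compound 3 with the change (methoxy in place of hydrogen on an aromatic carbon). Among the measured compounds shown here, this is the same kind of change as the one made from compound 1 to compound 2, but not the same: in compound 2 the entering methoxy sits ortho to a methoxy group and meta to the group of 9 heavy atoms, whereas in compound 4 it sits ortho to the group of 9 heavy atoms and meta to a methoxy group. Because the earlier step was a 1.1-fold higher number from compound 1 to compound 2 (0.04 log units; within the scatter), the step expected for compound 4 is a 1.2-fold higher number from compound 3 to compound 4 (0.07 log units; within the scatter), with the different surroundings of the new group and the different core adding some uncertainty. The estimate for compound 4 in this assay is therefore 40 uM, expected to fall between 15 uM and 110 uM.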

Compound 4, concentration for growth inhibition (reported as GI): 6.6 uM
The estimate for compound 4 lay 6.1-fold (0.78 log units) above the measured number; the measured number lies below the stated range.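

In this assay, methoxy in place of hydrogen on an aromatic carbon had a clear effect on the core of compound 3, giving a 5.1-fold lower number from compound 3 to compound 4 (0.71 log units; beyond the scatter), a step beyond the scatter that the earlier step on the core of compound 1 did not foreshadow. The size of this step therefore did not carry from one core to the other in these two cases: the same change on two cores in this assay, a 1.1-fold higher number (0.04 log units; within the scatter) from compound 1 to compound 2 and a 5.1-fold lower number (0.71 log units; beyond the scatter) from compound 3 to compound 4, 5.6-fold (0.75 log units) apart, beyond the scatter of two such steps This does not show that the core alone sets the size of the step, since the two steps also differ in the place of the entering methoxy, which in compound 4 sits ortho to a group of 9 heavy atoms and meta to a methoxy group, and the two pairs offer no way of separating core from place.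

Open, as far as these compounds go, is what a methoxy at this same place would do on the core of compound 1, and whether the same place on the core of compound 3 would respond in the same way to an ethoxy, a hydroxyl or an amine. Also open, from the compounds shown here alone, is whether a methoxy at the place it occupies in compound 2 would give a step of similar size on the core of compound 3.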